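The source may report more compounds than this note shows. Statements on the series, on what has been measured and on what is new or still open speak of the compounds shown alone.

Working notes on the series. In an ADME assay on MT4 cells (Homo sapiens) for cytotoxicity, read by MTT assay (a higher number here means that more compound is tolerated, a lower number that less compound is tolerated), compound 1 `S=C(Nc1ccccc1Cl)OCCc1ccccn1` returns only the assay limit, > 100000 nM, so no number is read for it. Going by the values given here, compound 2 `S=C(Nc1ccc(Cl)cc1)OCCc1ccccn1` is the sole member with a measured value in this assay, where compound 2 gives 52000 nM. The other value shown in this assay is a limit (the limit of > 100000 nM in this assay, at which 1 of the 2 values shown sits), which sets no order between the two. Compound 3 `S=C(Nc1ccc(Cl)cc1Cl)OCCc1ccccn1` has not yet been run in this assay; the change from compound 2 is chloro in place of hydrogen on an aromatic carbon. Among the compounds with values here, no measured step of this kind exists in the set, so its size can only be expected. A modest fall in tolerated concentration, beyond the scatter but not large, is expected, with the step from compound 2 to compound 3 estimated as a 1.7-fold lower number from compound 2 to compound 3 (0.24 log units; within the scatter). Compound 3 is therefore expected to give about 30000 nM in this assay, within 8000 nM to 100000 nM, and a limit reading is not excluded.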

Compound 3, half-maximal cytotoxic concentration: > 100000 nM
Compound 3: only a limit was reported; the forecaster's own chance of this, stated with the estimate: 25%; middle value at least 3.3-fold (0.52 log units) from the limit.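

In this assay, the series now holds its first readable step for chloro in place of hydrogen on an aromatic carbon, here ortho to a large group and meta to a chloro group: it is an at least 1.9-fold higher number from compound 2 to compound 3 (0.28 log units; that floor lies within the scatter). This is a floor rather than a size, and as it lies within the scatter, it does not separate the two compounds. The step between compound 1 and compound 3 cannot be read, as both readings are limits, and limits now make up most of the set: the limit of > 100000 nM in this assay, at which 2 of the 3 values shown sit.

The compounds shown leave open whether an amine or a carboxylic acid at this position would give a measured number in this assay. They also leave open how a longer chain in place of chloro would read there.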